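Methoxy to trifluoromethoxy on the shared core

The compounds below may be only part of what the source reports. "The series", "measured", "known", "first", "only" and "open" are said of these compounds alone.

For the measured compounds named here, in a functional assay on HT-29 cells (Homo sapiens) for inhibition (a higher number here means a weaker inhibitor, a lower number a stronger inhibitor), compound 1 `COc1cccc(/C=C\c2ccc3ccccc3c2)c1` gives 1920 nM as the higher of the two numbers so far. Compound 2 `COc1cc(/C=C\c2ccc3ccccc3c2)ccc1F` gives 450 nM in the same read-out. Going by the values given here, compound 3 `FC(F)(F)Oc1cccc(/C=C\c2ccc3ccccc3c2)c1` is still unmeasured and differs from compound 1 by trifluoromethyl in place of methyl on an oxygen on an aromatic ring as its one change: trifluoromethyl in place of methyl on an oxygen on an aromatic ring, or methoxy to trifluoromethoxy.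

Among the compounds with values here, the only measured step is a 4.3-fold lower number from compound 1 to compound 2 (0.63 log units; beyond the scatter) for fluoro in place of hydrogen on an aromatic carbon. Within the data shown here, that step is modest and bears only loosely, since it is a different change and no measured step touches the methoxy group. No direction carries over, so no step beyond the scatter is expected in this assay here. The expected step is a 1.1-fold lower number from compound 1 to compound 3 (0.05 log units; within the scatter) as a working estimate. For compound 3 the estimated value is 1700 nM with an expected range from 500 nM to 6000 nM for now.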

Compound 3, half-maximal inhibitory concentration: 3500 nM
The estimate for compound 3 lay 2.1-fold (0.31 log units) below the measured number, and the stated range covers the measured number.
By their numbers in this assay, from the lowest: compound 2; then compounds 1 and 3 (each within the scatter of the next).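

In this assay, trifluoromethyl in place of methyl on an oxygen on an aromatic ring gives a 1.8-fold higher number from compound 1 to compound 3 (0.26 log units; within the scatter), so exchanging one heavy atom for four at this position produces no step beyond the scatter. For the compounds shown here, this is the first reading on the methoxy group itself, which the fluoro step, a 4.3-fold lower number from compound 1 to compound 2 (0.63 log units; beyond the scatter), did not touch, and in this read-out the methyl can be replaced by trifluoromethyl without a measurable loss or gain. No measured evidence accounts for this result.

Still open, on these data alone, is whether a longer chain such as ethoxy, a hydroxyl or an amine at this place would also stay within the scatter of compound 1. Also open, as far as these compounds go, is whether trifluoromethoxy and the fluoro group of compound 2 would combine on the shared core, and what that combination would give.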